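This account rests on a few compounds, and the source may have more. Where it says the series, first, only, none or still open, it means among the compounds named here.

Compound 2, `Cc1ccccc1NC(=O)NC1CC(C)(C)Oc2ccc(Cl)cc21`, is one of three close relatives that share a core and differ only in the halogen on the fused ring. In a functional assay (aorta) with Rattus norvegicus as the target (a lower number here means that less compound is needed, a higher number that more compound is needed for the effect), compound 2 gives > 10000 nM, which is a limit of the assay rather than a number. Compound 1, `Cc1ccccc1NC(=O)NC1CC(C)(C)Oc2ccc(F)cc21`, gives > 30000 nM, again a limit. Compound 3, `Cc1ccccc1NC(=O)NC1CC(C)(C)Oc2ccc(Br)cc21`, gives > 30000 nM, also a limit. The steps a step that the two limits leave unreadable from compound 1 to compound 2, a step that the two limits leave unreadable from compound 1 to compound 3 and a step that the two limits leave unreadable from compound 2 to compound 3 therefore cannot be sized; the values sit at the limit of > 10000 nM in this assay, at which 1 of the 3 values shown sits, and (the limit of > 30000 nM in this assay, at which 2 of the 3 values shown sit).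

Compound 4, `CC1(C)CC(NC(=O)Nc2ccccc2Cl)c2cc(Cl)ccc2O1`, changes a different ring: chloro in place of methyl on an aromatic carbon. Going by the values given here, no measured step touches this position, so nothing here suggests a gain. Compound 4 is expected at 30000 nM, within 8000 nM to 100000 nM. The expected step is a step that the limit leaves unreadable from compound 2 to compound 4.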

Compound 4, half-maximal effective concentration: > 300000 nM
Compound 4 gave a limit, no number; the forecaster's own chance of this, stated with the estimate: 80%; middle value at least 10-fold (1.00 log units) from the limit.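

In this assay compound 2 and compound 4 each give only a limit, so the step between them cannot be read. The compounds shown leave open whether either 2-chlorophenyl in place of 2-methylphenyl or a different halogen changes the concentration needed at all.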